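Trading the Trimethoxyphenyl for Phenyl on Compound 2

The compounds below may be only part of what the source reports. "The series", "measured", "known", "first", "only" and "open" are said of these compounds alone.

Of the compounds shown here, two built on one shared core have been measured in a functional assay on B16-F10 cells (Mus musculus) for inhibition, read by MTT assay, with a stated time of 72 h; a higher number here means a weaker inhibitor, a lower number a stronger inhibitor. Compound 1 `COc1cc(-c2nc(SCc3cn(CC(=O)NC(=O)Nc4ccccn4)nn3)nc(Nc3ccc(C(C)C)cc3)c2C#N)cc(OC)c1OC` gives 1210 nM in this assay. Compound 2 `COc1cc(-c2nc(SCc3cn(CC(=O)NC(=O)Nc4ccccn4)nn3)nc(Nc3ccc(C)cc3)c2C#N)cc(OC)c1OC` gives 32 nM in this assay. Among the compounds with values here, the single measured step, a 38-fold lower number from compound 1 to compound 2 (1.58 log units; beyond the scatter), separates them, and compound 2 therefore stands with the lowest of the two numbers; its nearest neighbour is compound 1, whose number is higher by a margin beyond the scatter.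

Compound 3 `Cc1ccc(Nc2nc(SCc3cn(CC(=O)NC(=O)Nc4ccccn4)nn3)nc(-c3ccccc3)c2C#N)cc1` has not yet been measured. It differs from compound 2 by phenyl in place of 3,4,5-trimethoxyphenyl on an aromatic carbon. Within the data shown here, no measured step touches this part of the molecule: the one known step concerns the (4-methylphenyl)amino group, not the 3,4,5-trimethoxyphenyl, so it offers no guide to the size or direction of the change now in question. The expectation is accordingly loose. Compound 3 is estimated at 250 nM in this assay, with a range from 40 nM to 1600 nM. The expected step, a 7.8-fold higher number from compound 2 to compound 3 (0.89 log units; beyond the scatter), is a probable but uncertain rise in the number.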

Compound 3, half-maximal inhibitory concentration: 3300 nM
Beside the measured number, compound 3's estimate is 13-fold (1.12 log units) below it; the whole stated range lies below it.
By their numbers in this assay, from the lowest: compound 2; then compound 1; then compound 3.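

In this assay, the step to phenyl in place of 3,4,5-trimethoxyphenyl gives a 100-fold higher number from compound 2 to compound 3 (2.01 log units; beyond the scatter), so the group on this aromatic carbon, next to the ring nitrogen and ortho to a cyano group, has a large bearing on the number. Within the data shown here, until now, the only measured change was on the (4-methylphenyl)amino side, with a 38-fold lower number from compound 1 to compound 2 (1.58 log units; beyond the scatter), and it said nothing about this second place on the shared core. The new step shows that the low number of compound 2 depends on keeping the 3,4,5-trimethoxyphenyl as well as the methyl, and the data shown offer no explanation for the rise.

The change takes away all three methoxy groups at once, so the compounds shown leave open whether the number follows their count or rests on one of them, which a phenyl carrying one or two methoxy groups would test. Also open, on these data alone, is how a phenyl bearing a hydroxy group or a fluorine at this place would read, and whether the isopropyl group would give a step of similar size here.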